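Swapping cyclohexyl for isopropyl on the amide carbonyl

The source may report more compounds than this note shows. Statements on the series, on what has been measured and on what is new or still open speak of the compounds shown alone.

Compound 1: `COC(=O)/C=C/c1cccc(N(Cc2ccc(/C=C/c3ccccn3)cc2)C(=O)C(C)C)c1`, giving 310 nM
Compound 2: `COC(=O)/C=C/c1cccc(N(Cc2ccc(-c3cccc(C)c3)cc2)C(=O)C2CCCCC2)c1`, giving 109 nM

Both compounds were tested in an assay on isolated protein with Bile acid receptor (Homo sapiens) as the target; on this read-out lower numbers stand for an effect already at smaller amounts and higher numbers for an effect only at larger amounts of compound. Compound 2 gives the lowest of the two numbers, and compound 1 gives a number that lies beyond the usual scatter above it. Compound 3, `COC(=O)/C=C/c1cccc(N(Cc2ccc(-c3cccc(C)c3)cc2)C(=O)C(C)C)c1`, keeps the rest of compound 2 and differs in one place only: isopropyl in place of cyclohexyl on a carbonyl carbon. Within the data shown here, no measured pair shows this change on its own, so its size is uncertain. A modest loss is expected, as the step of a 2.8-fold higher number from compound 2 to compound 3 (0.44 log units; beyond the scatter). Compound 3 is estimated at 300 nM, in a range from 100 nM to 1000 nM.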

Compound 3, half-maximal effective concentration: 163 nM
For compound 3 the middle estimate is 1.8-fold (0.26 log units) above the measured one, and the stated range covers the measured number.
By their numbers in this assay, from the lowest: compounds 2, 3 and 1 (each within the scatter of the next, the first and the last beyond it).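

On a carbonyl carbon, the six-membered carbon ring of cyclohexyl can give way to the open isopropyl with a change that stays within the scatter in this assay (a 1.5-fold higher number from compound 2 to compound 3 (0.17 log units; within the scatter)). On an aromatic carbon, 3-methylphenyl in place of 2-(pyridin-2-yl)ethenyl also stays within the scatter (a 1.9-fold lower number from compound 1 to compound 3 (0.28 log units; within the scatter)), so neither single change separates these compounds clearly. Nothing shown here explains either result. As far as these compounds go, whether a methyl group, a tert-butyl group or an amine on that carbonyl carbon would keep the number in this range remains open.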